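Ester chain branching in the hydroxy ester series

The source may report more compounds than this note shows. Statements on the series, on what has been measured and on what is new or still open speak of the compounds shown alone.

Compound 3 `CCCOC(=O)C(O)Cn1cnc2c(N)ncnc21` gives only a limit in a functional assay on HeLa cells (Homo sapiens) for cytotoxicity; on this read-out higher numbers stand for lower toxicity in this test and lower numbers for higher toxicity in this test: its value of > 400 ug/mL is a limit of the assay and not a number. Compound 1 `COC(=O)C(O)Cn1cnc2c(N)ncnc21` likewise stops at a limit, > 400 ug/mL. Compound 2 `Nc1ncnc2c1ncn2CC(O)C(=O)OC1CCCCC1` gives 100 ug/mL in this assay. The steps of an at least 4.0-fold lower number from compound 1 to compound 2 (0.60 log units; beyond the scatter) and an at least 4.0-fold higher number from compound 2 to compound 3 (0.60 log units; beyond the scatter) both single out the cyclohexyl ester, whereas the chain growth a step that the two limits leave unreadable from compound 1 to compound 3 rests on the limit of > 400 ug/mL in this assay, at which 2 of the 3 values shown sit, and cannot be read.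

Compound 4 `CC(C)COC(=O)C(O)Cn1cnc2c(N)ncnc21` differs from compound 3 by methyl in place of hydrogen on a saturated chain carbon bound to two saturated chain carbons. For the measured compounds named here, the only comparable change, the chain growth from compound 1 to compound 3, left no readable step, so no step beyond the scatter is expected: a number no higher from compound 3 to compound 4 (the limit leaves the size open). Compound 4 is therefore estimated at 400 ug/mL, within 200 ug/mL to 800 ug/mL, most likely reported again as a limit.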

Compound 4, minimum cytotoxic concentration: > 400 ug/mL
Compound 4: a limit, no number (the forecaster's own chance of this, stated with the estimate: 70%); the middle value lies on the limit itself.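

In this assay the isobutyl ester stays clearly apart from the cyclohexyl ester, with an at least 4.0-fold higher number from compound 2 to compound 4 (0.60 log units; beyond the scatter), so branching of the open chain does not reproduce the cyclohexyl result. Compound 4 gives > 400 ug/mL, a limit of the assay and not a number. The steps among compound 1, compound 3 and compound 4 cannot be read: the limit of > 400 ug/mL in this assay, at which 3 of the 4 values shown sit.

Open, from the compounds shown here alone, is whether a longer chain such as hexyl or a smaller ring such as cyclopentyl on the ester oxygen also lowers the number. Going by these compounds, the free carboxylic acid in place of the ester is equally open.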